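Adding a hex-5-en-1-yl group to compound 3

This account rests on a few compounds, and the source may have more. Where it says the series, first, only, none or still open, it means among the compounds named here.

In a functional assay on SK-MEL-28 cells (Homo sapiens) for inhibition, read by colorimetric assay and MTT assay, with a stated time of 72 h (on this read-out lower numbers stand for stronger inhibition and higher numbers for weaker inhibition), compound 3 `Cn1c(-c2ccccc2O)cnc1S(=O)(=O)c1ccccc1` gives only a limit, > 100000 nM, and not a number. Within the data shown here, it is the one compound of the three measured that stands there: the limit of > 100000 nM in this assay, at which 1 of the 3 values shown sits.

Compound 4 `C=CCCCCOc1ccccc1-c1cnc(S(=O)(=O)c2ccccc2)n1C` is made from compound 3 by one change, hex-5-en-1-yl in place of hydrogen on an oxygen on an aromatic ring, so that hydroxy becomes (hex-5-en-1-yl)oxy: hex-5-en-1-yl in place of hydrogen on an oxygen on an aromatic ring.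

Among the measured compounds shown here, no measured step tests this change directly. Two related compounds do already carry the (hex-5-en-1-yl)oxy group: in this assay, compound 1 `C=CCCCCOc1ccccc1-c1cnc(OCCCC=C)n1C` gives 19000 nM and compound 2 `C=CCCCCOc1ccccc1-c1cnc(OCCOCC=C)n1C` gives 59000 nM. For the measured compounds named here, the only measured step is a 3.1-fold higher number from compound 1 to compound 2 (0.49 log units; beyond the scatter). Going by the values given here, it concerns a different group, so it shows only that a change elsewhere in these structures can move the number by a modest amount.

Both compound 1 at 19000 nM and compound 2 at 59000 nM give measured numbers, so a move towards stronger inhibition is expected, though its size stays uncertain. The estimated step is an at least 4.0-fold lower number from compound 3 to compound 4 (0.60 log units; beyond the scatter). For compound 4 the estimate is 25000 nM, with an expected range from 7000 nM to 90000 nM.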

Compound 4, half-maximal inhibitory concentration: 38000 nM
For compound 4 the middle estimate is 1.5-fold (0.18 log units) below the measured one; the measured number falls inside the stated range.
By their numbers in this assay, from the lowest: compounds 1, 4 and 2 (each within the scatter of the next, the first and the last beyond it). At a limit, above all of these: compound 3.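

Among these compounds, the first direct reading of this change comes from this assay: hex-5-en-1-yl in place of hydrogen on an oxygen on an aromatic ring gives a real gain in inhibition (an at least 2.6-fold lower number from compound 3 to compound 4 (0.42 log units; beyond the scatter)). The value of compound 3 is a limit and not a number, so this step gives only the smallest size the gain can have: the limit of > 100000 nM in this assay, at which 1 of the 4 values shown sits. The phenylsulfonyl group, for its part, reads much like the two groups it can be set against on the aromatic carbon, whether it takes the place of 2-(allyloxy)ethoxy (a 1.6-fold lower number from compound 2 to compound 4 (0.19 log units; within the scatter)) or of (pent-4-en-1-yl)oxy (a 2.0-fold higher number from compound 1 to compound 4 (0.30 log units; within the scatter)), and both of these steps stay within the scatter.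

The compounds shown leave open whether the gain needs the full hex-5-en-1-yl chain and its double bond, or whether a plain methyl, a saturated hexyl chain or a chain ending in an amine on the same oxygen would read the same. They also leave open how the hydroxy group would read with (pent-4-en-1-yl)oxy in place of phenylsulfonyl on the aromatic carbon.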